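Swapping the anilide aryl group: compound 1 to compound 3

This account rests on a few compounds, and the source may have more. Where it says the series, first, only, none or still open, it means among the compounds named here.

In a functional assay on HeLa cells (Homo sapiens) for inhibition, read by MTT assay, with a stated time of 48 h (a lower number here means a stronger inhibitor, a higher number a weaker inhibitor), compound 1 `COc1cc(/C=C/C(=O)Nc2ccccc2N)ccc1OCC(=O)Nc1cccc(F)c1` gives 28100 nM and compound 2 `COc1cc(/C=C/C(=O)NO)ccc1OCC(=O)Nc1cccc(F)c1` gives 34500 nM, so compound 1 has one neighbour on the numbers and sits within the scatter of it. Compound 3 `COc1ccc(NC(=O)COc2ccc(/C=C/C(=O)Nc3ccccc3N)cc2OC)cc1` carries 4-methoxyphenyl in place of 3-fluorophenyl on an amide-type nitrogen. Within the data shown here, the only measured step, a 1.2-fold higher number from compound 1 to compound 2 (0.09 log units; within the scatter), puts hydroxy in place of 2-aminophenyl on an amide-type nitrogen and leaves the 3-fluorophenyl untouched. It therefore bears only indirectly, showing a flat pair of values. Among the measured compounds shown here, no measured step covers a change of this aryl group, so no direction can be drawn from the data. In this assay, the expected result is no change beyond the scatter, with an estimated 1.1-fold lower number from compound 1 to compound 3 (0.05 log units; within the scatter). For compound 3 the estimate is 25000 nM, with an expected range of 9000 nM to 60000 nM.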

Compound 3, half-maximal inhibitory concentration: > 100000 nM
Compound 3: a limit, no number; the forecaster's own chance of this, stated with the estimate: 10%; middle value at least 4.0-fold (0.60 log units) away from the limit.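

In this assay, among these compounds, the group on the amide-type nitrogen is the first place in this set where a single change moves the read-out beyond the scatter, with 4-methoxyphenyl in place of 3-fluorophenyl giving an at least 3.5-fold higher number from compound 1 to compound 3 (0.55 log units; beyond the scatter). The earlier step, a 1.2-fold higher number from compound 1 to compound 2 (0.09 log units; within the scatter), changed a different group and stayed within the scatter, so this aryl position is the only one shown here to affect the read-out. Compound 3 gives a limit of the assay and not a number, so the full size of this step stays unknown: the limit of > 100000 nM in this assay, at which 1 of the 3 values shown sits.

Still open, going by these compounds, is whether the departure of 3-fluorophenyl or the arrival of 4-methoxyphenyl carries the step, and whether plain phenyl or 3-methoxyphenyl on this nitrogen would match compound 1. Also open, on these data alone, is whether hydroxy in place of 2-aminophenyl would leave compound 3 at the same limit.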